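Cyclopentyl in place of cyclopropyl on the amine carbon

This account rests on a few compounds, and the source may have more. Where it says the series, first, only, none or still open, it means among the compounds named here.

Measured in an assay on CHO cells for displacement of a labelled ligand from C-X-C chemokine receptor type 3 (Homo sapiens), with a stated time of 60 min; on this read-out higher numbers stand for weaker inhibition and lower numbers for stronger inhibition:
compound 1 `Cc1cc(CN(CC2CC2)C(CC(=O)O)c2ccc(Cl)cc2)ccc1OCCN1C(=O)CCC1=O` gives 65 nM
compound 2 `Cc1cc(CN(CC2CC2)[C@@H](CC(=O)O)c2ccc(Cl)cc2)ccc1OCCN1C(=O)CCC1=O` gives 42 nM

Compound 2 has the lowest of the two numbers in this assay, with compound 1 as its nearest neighbour; the step from compound 1 to compound 2 is a 1.5-fold lower number from compound 1 to compound 2 (0.19 log units; within the scatter), so the two cannot be ordered. That step is the only one measured, and it rests on the fact that one of compounds 1 and 2 is drawn with a defined configuration and the other without, at the place where they differ alone: nothing in it touches the group on the amine nitrogen.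

Compound 3 `Cc1cc(CN(CC2CCCC2)[C@@H](CC(=O)O)c2ccc(Cl)cc2)ccc1OCCN1C(=O)CCC1=O` is not yet measured. It differs from compound 2 by cyclopentyl in place of cyclopropyl on a saturated chain carbon bound to an amine nitrogen. Going by the values given here, no measured step bears on this change; the pair 1 and 2 shows only that the configuration at the chain carbon moves the number within the scatter. With no evidence on the ring size at this position, no step beyond the scatter is expected in either direction, but the range must be wide.

Compound 3 is therefore expected to give 45 nM in this assay, between 15 nM and 140 nM, a step of a 1.1-fold higher number from compound 2 to compound 3 (0.03 log units; within the scatter).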

Compound 3, half-maximal inhibitory concentration: 36 nM
The estimate for compound 3 lay 1.3-fold (0.10 log units) above the measured number, within the range that was stated.
By their numbers in this assay, from the lowest: compounds 3, 2 and 1 (each within the scatter of the next).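

In this assay, the change on the amine nitrogen side, cyclopentyl in place of cyclopropyl on a saturated chain carbon bound to an amine nitrogen, gives a 1.2-fold lower number from compound 2 to compound 3 (0.07 log units; within the scatter), so the two compounds cannot be ordered. Compounds 1 and 2 both carry cyclopropyl at this place and said nothing about it; the new pair shows that a five-membered non-aromatic ring of carbon only can stand here in place of the three-membered one with the number staying within the scatter. Going by these compounds alone, nothing measured so far gives a reason for this result, as the only earlier comparison concerns the drawn configuration at another carbon.

The shown compounds carry only these two rings at this place, so it remains open whether a cyclohexyl ring, a phenyl ring, a ring holding an oxygen such as tetrahydropyranyl, or an open chain such as isobutyl would keep the number in the same range. Also open, going by these compounds, is whether the same exchange reads the same way with the carboxylic acid replaced by an amide or with the opposite configuration at the chain carbon.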